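The source may hold more compounds than are shown below. What is called first, only, known or untested is meant among the compounds shown, and "the series" means these compounds.

Measured so far:
compound 1, `COc1cc(N)c(Cl)cc1NC(=O)C1CCN(Cc2ccc(Cl)cc2)CC1`: 1.2 mg/kg
compound 2, `COc1cc(N)c(Cl)cc1NC(=O)C1CCN(CC2CCCCCC2)CC1`: > 10 mg/kg
compound 3, `COc1cc(N)c(Cl)cc1NC(=O)C1CCN(C2CCCC2)CC1`: > 10 mg/kg

Among the compounds with values here, in a functional assay on the whole organism for antagonist activity, with Mus musculus as the target (a lower number here means that less compound is needed, a higher number that more compound is needed for the effect), compound 1 gives 1.2 mg/kg, the only number among the three values. Compound 2 reaches only a limit of the assay, > 10 mg/kg. Compound 3 likewise reaches only a limit, > 10 mg/kg. Two of the three values thus sit at the limit of > 10 mg/kg in this assay, at which 2 of the 3 values shown sit. Both readable steps cost at least modestly: an at least 8.3-fold higher number from compound 1 to compound 2 (0.92 log units; beyond the scatter) and an at least 8.3-fold higher number from compound 1 to compound 3 (0.92 log units; beyond the scatter). Between the two limits, a step that the two limits leave unreadable from compound 2 to compound 3.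

Compound 4, `COc1cc(N)c(Cl)cc1NC(=O)C1CCN(Cc2ccccc2F)CC1`, is not yet measured. Its change from compound 1: 2-fluorophenyl in place of 4-chlorophenyl on a saturated chain carbon bound to an amine nitrogen in a ring. The aromatic ring stays and only the halogen changes. Neither measured step bears directly on this, since both measured steps remove the aromatic ring altogether and replace it with a saturated one; they only show that the aromatic ring matters, which compound 4 keeps.

Compound 4 is therefore expected to stay close to compound 1, with a small rise allowed, a 1.7-fold higher number from compound 1 to compound 4 (0.22 log units; within the scatter). The estimate for compound 4 in this assay is 2 mg/kg, expected to fall between 0.6 mg/kg and 8 mg/kg.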

Compound 4, dose for half-maximal effect: > 4 mg/kg
Compound 4 was reported as a limit; the forecaster's own chance of this, stated with the estimate: 15%; middle value at least 2.0-fold (0.30 log units) away from the limit.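

Keeping an aromatic ring on the saturated chain carbon bound to the amine nitrogen in a ring does not by itself preserve the result of compound 1 in this assay: the change to 2-fluorophenyl gives an at least 3.3-fold higher number from compound 1 to compound 4 (0.52 log units; beyond the scatter). The result for compound 4 is a limit and not a number: the limit of > 4 mg/kg in this assay, at which 1 of the 4 values shown sits. At this position, then, the halogen substitution on the aromatic ring matters as well as the presence of that ring, while the steps from compound 2 and compound 3 to compound 4 cannot be read, both ends being limits.

This change alters the halogen and its place on the ring together, and the compounds shown do not separate the two; 4-fluorophenyl or 2-chlorophenyl would. On these data alone, the true size of the step to compound 4 stays open, as does the standing of an unsubstituted phenyl at this place.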